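A few compounds are considered here, and "the series" means these few. Any claim that something is new, unique, unknown or untested is made for them only; others in the source may bear on it.

Compound 1 `CC(C)NC(=O)CC(c1ccc(-c2ccc3cccc(F)c3c2)[nH]c1=O)C(C)C`: < 0.0667 h
Compound 2 `CC(C)C(Cc1nnn[nH]1)c1ccc(-c2ccc3cccc(F)c3c2)[nH]c1=O`: 0.853 h
Compound 3 `CC(C)C(CC(N)=O)c1ccc(-c2ccc3cccc(F)c3c2)[nH]c1=O`: < 0.0667 h

The three measured compounds share one core and differ only in the group on the saturated chain carbon. In an ADME assay on microsomes from liver (Mus musculus) for metabolic stability (a higher number here means that the compound lasts longer, a lower number that the compound disappears faster), compound 3 gives < 0.0667 h, which is a limit of the assay rather than a number (the limit of < 0.0667 h in this assay, at which 2 of the 3 values shown sit). Compound 1 sits at that same limit. Compound 2 gives 0.853 h in this assay. Compound 4 `CC(C)C(Nc1nnc[nH]1)c1ccc(-c2ccc3cccc(F)c3c2)[nH]c1=O` has not yet been measured; ((4H-1,2,4-triazol-3-yl)amino in place of carbamoylmethyl on a saturated chain carbon bound to an aromatic carbon and a saturated chain carbon). Among the measured compounds shown here, two measured steps bear on this change: an at least 12-fold lower number from compound 2 to compound 3 (1.10 log units; beyond the scatter) and an at least 12-fold higher number from compound 1 to compound 2 (1.10 log units; beyond the scatter). In both, the compound carrying a five-membered aromatic ring with hetero atoms lasts longer than the amide partner. The entering group brings such a ring, so an upward step is expected, an at least 5.9-fold higher number from compound 3 to compound 4 (0.77 log units; beyond the scatter). Compound 4 is estimated at 0.4 h, ranging from 0.1 h to 1.5 h.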

Compound 4, half-life: 2.42 h
Beside the measured number, compound 4's estimate is 6.1-fold (0.78 log units) below it, outside the stated range (above it).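

In this assay the (4H-1,2,4-triazol-3-yl)amino group gives an at least 36-fold higher number from compound 3 to compound 4 (1.55 log units; beyond the scatter) and an at least 36-fold higher number from compound 1 to compound 4 (1.55 log units; beyond the scatter) against the two amide compounds. Putting it in place of (1H-tetrazol-5-yl)methyl still gives a 2.8-fold higher number from compound 2 to compound 4 (0.45 log units; beyond the scatter) and so the two compounds with a five-membered aromatic ring also differ from each other, not only from the amides. The two large steps start from a limit of the assay rather than a number: the limit of < 0.0667 h in this assay, at which 2 of the 4 values shown sit.

Still open, going by these compounds, is whether the ring or its amino link matters more. A plain amine on the same carbon, or a longer chain between that carbon and the triazole, would help separate the two.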